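Replacing the trifluoromethylpyridine of compound 2 with tert-butylphenyl

The source may hold more compounds than are shown below. What is called first, only, known or untested is meant among the compounds shown, and "the series" means these compounds.

Compound 1 `CCc1nc2cc(Cl)ccn2c1C(=O)NCc1ccc2c(c1)CCN(Cc1ccc(OC)cc1)C2`: 32 ug/mL
Compound 2 `CCc1nc2ccc(Cl)cn2c1C(=O)NCc1ccc2c(c1)CCN(Cc1ccc(C(F)(F)F)nc1)C2`: 7 ug/mL
Compound 3 `CCc1nc2ccc(Cl)cn2c1C(=O)NCc1ccc2c(c1)CCN(Cc1ccc(C)cc1)C2`: 51 ug/mL

In an ADME assay on Vero cells (Chlorocebus sabaeus) for cytotoxicity, read by MTT assay, with a stated time of 72 h (on this read-out lower numbers stand for higher toxicity in this test and higher numbers for lower toxicity in this test), compound 2 gives the lowest number of the three, with compound 1 and compound 3 both beyond the scatter above it. Compound 4 `CCc1nc2ccc(Cl)cn2c1C(=O)NCc1ccc2c(c1)CCN(Cc1ccc(C(C)(C)C)cc1)C2` is the next to be read, and it carries this change: 4-(tert-butyl)phenyl in place of 6-(trifluoromethyl)pyridin-3-yl on a saturated chain carbon bound to an amine nitrogen in a ring. Among the compounds with values here, the one measured step at this place is a 7.3-fold higher number from compound 2 to compound 3 (0.86 log units; beyond the scatter), which lies beyond the scatter and also brings in a carbon-only aromatic ring. A rise in this assay is therefore expected, of similar or somewhat smaller size. The expected change is a 3.6-fold higher number from compound 2 to compound 4 (0.55 log units; beyond the scatter). For compound 4 the estimated value is 25 ug/mL, with an expected range of 9 ug/mL to 60 ug/mL.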

Compound 4, half-maximal cytotoxic concentration: 37 ug/mL
For compound 4 the middle estimate is 1.5-fold (0.17 log units) below the measured one, and the stated range covers the measured number.
By their numbers in this assay, from the lowest: compound 2; then compounds 1, 4 and 3 (each within the scatter of the next).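

In this assay, a second carbon-only aromatic ring gives a 5.3-fold higher number from compound 2 to compound 4 (0.72 log units; beyond the scatter) and so rises in the same direction as compound 3 did, which shows that this rise is not confined to the methyl-bearing ring. The size of the group on that ring makes no readable difference here: the step of tert-butyl in place of methyl is a 1.4-fold lower number from compound 3 to compound 4 (0.14 log units; within the scatter) and stays within the scatter. Nothing measured explains either step.

From the compounds shown here alone, it remains open whether the low number of compound 2 goes with the pyridine nitrogen or with the trifluoromethyl group. A trifluoromethylphenyl group and a methylpyridine would separate the two.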